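The source may hold more compounds than are shown below. What is called first, only, known or untested is meant among the compounds shown, and "the series" means these compounds.

In a functional assay on KB cells (Homo sapiens) for cytotoxicity (on this read-out lower numbers stand for an effect already at smaller amounts and higher numbers for an effect only at larger amounts of compound), three compounds that share one core give nearly the same number: compound 1 `COC1=C(C)C(=O)/C(=C(O)/C=C/c2ccccc2OC)C(=O)C1(C)C` gives 3.3 ug/mL, compound 2 `COC1=C(C)C(=O)/C(=C(O)/C=C/c2ccc(O)cc2)C(=O)C1(C)C` gives 3.8 ug/mL, and compound 3 `COC1=C(C)C(=O)/C(=C(O)/C=C/c2ccc(C)cc2)C(=O)C1(C)C` gives 3.9 ug/mL. Compound 3 thus stands level with the other two, within the scatter. Compound 4 `COC1=C(C)C(=O)/C(=C(O)/C=C/c2cc(C)cc(C)c2)C(=O)C1(C)C` differs from compound 3 in one place: 3,5-dimethylphenyl in place of 4-methylphenyl on a double-bonded chain carbon bound to a double-bonded chain carbon. The measured steps that bear on this swap the aromatic group or its substituent: a 1.2-fold higher number from compound 1 to compound 3 (0.07 log units; within the scatter), a 1.2-fold higher number from compound 1 to compound 2 (0.06 log units; within the scatter) and a 1.0-fold higher number from compound 2 to compound 3 (0.01 log units; within the scatter). For the measured compounds named here, all three stay within the scatter, although no measured compound carries 3,5-dimethylphenyl. In this assay, no step beyond the scatter is therefore expected, and the estimated change is a 1.1-fold lower number from compound 3 to compound 4 (0.02 log units; within the scatter). Compound 4 is expected to give 3.7 ug/mL, within an estimated range of 1.9 ug/mL to 7 ug/mL.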

Compound 4, concentration for half-maximal effect: 3.1 ug/mL
The estimate for compound 4 lay 1.2-fold (0.08 log units) above the measured number; the measured number falls inside the stated range.
By their numbers in this assay, from the lowest: compounds 4, 1, 2 and 3 (each within the scatter of the next).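

In this assay, 3,5-dimethylphenyl at this place on the chain gives a 1.3-fold lower number from compound 3 to compound 4 (0.10 log units; within the scatter), with a 1.2-fold lower number from compound 2 to compound 4 (0.09 log units; within the scatter) and a 1.1-fold lower number from compound 1 to compound 4 (0.03 log units; within the scatter), so a ring carrying two methyl groups stays level with the three earlier aromatic groups, all within the scatter. Nothing available here explains this flat result. Every compound shown carries a substituted phenyl ring at this place, so it remains open whether an amine, a carboxylic acid or a longer chain there would move the number beyond the scatter.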